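Chlorobenzyl variants on two amide cores: working notes

The compounds below may be only part of what the source reports. "The series", "measured", "known", "first", "only" and "open" are said of these compounds alone.

Compound 1 `CC1=C(C(=O)Nc2ccc(Br)cc2)C(c2ccc(Cl)cc2Cl)N=C(SCc2ccccc2)N1` and compound 2 `CC1=C(C(=O)Nc2ccc(Br)cc2)C(c2ccc(Cl)cc2Cl)N=C(SCc2ccc(Cl)cc2)N1` share one core; compound 3 `CC1=C(C(=O)Nc2ccc([N+](=O)[O-])cc2)C(c2cccc([N+](=O)[O-])c2)N=C(SCc2ccccc2)N1` and compound 4 `CC1=C(C(=O)Nc2ccc([N+](=O)[O-])cc2)C(c2cccc([N+](=O)[O-])c2)N=C(SCc2ccccc2Cl)N1` share another, and the difference between the two cores is not broken down here. In a functional assay on the whole organism (artery, strain albino) with Rattus norvegicus as the target, with a stated time of 15 min, at a dose of 10 mg/kg by the oral route (a higher number here means more inhibition at the dose given (going by the name of the read-out), a lower number less inhibition), compound 1 gives 1.5%, compound 2 gives 4.1% and compound 3 gives 2.6%; all three lie within the scatter of one another. The change from compound 1 to compound 2 is chloro in place of hydrogen on an aromatic carbon, which gave a number 2.6 percentage points higher from compound 1 to compound 2 (within the scatter). The change from compound 3 to compound 4 is chloro in place of hydrogen on an aromatic carbon; it is the same kind of change, but the chloro enters ortho to a large group rather than para to a large group. In this assay the expected step is a number 1.4 percentage points higher from compound 3 to compound 4 (within the scatter). That expectation rests on the earlier step because a number 2.6 percentage points higher from compound 1 to compound 2 (within the scatter). Compound 4 is therefore estimated at 4%, between -6% and 14%.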

Compound 4, a percentage reported as inhibition, in the whole organism at one dose (the size of the read-out at that dose, not a potency): 2.1%
Beside the measured number, compound 4's estimate is 1.9 percentage points above it, and the stated range covers the measured number.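

In this assay, phenyl to 2-chlorophenyl within the benzylsulfanyl group gives a number 0.5 percentage points lower from compound 3 to compound 4 (within the scatter). Set beside the step on the other core, this shows no difference between the two cores: the same change on two cores in this assay, a number 2.6 percentage points higher (within the scatter) from compound 1 to compound 2 and a number 0.5 percentage points lower (within the scatter) from compound 3 to compound 4, 3.1 percentage points apart, within the scatter of two such steps

This does not show that a real effect of the chloro carries over, since neither step can be told from no change, and with one pair per core, the core cannot be separated from where the chloro enters, here ortho to a large group.

Open, going by these compounds, is whether any other group at this end of the molecule moves the inhibition beyond the scatter. An amine, a carboxylic acid or a longer chain in place of the benzyl group would test that.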